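The compounds below may be only part of what the source reports. "The series", "measured", "known", "first", "only" and "open" are said of these compounds alone.

Compound 1, `O=C1N/C(=N/c2csc(-c3ccc(Cl)cc3)c2)S/C1=C\c1ccccc1`: in a functional assay on HT-29 cells (Homo sapiens) for cytotoxicity, read by MTT assay, with a stated time of 72 h (on this read-out lower numbers stand for stronger inhibition and higher numbers for weaker inhibition), compound 1 gives 10500 nM.
Compound 2, `Cc1ccc(/C=C2\S/C(=N\c3csc(-c4ccc(Cl)cc4)c3)NC2=O)cc1`: in this assay compound 2 gives 6400 nM.
Compound 3, `COc1cccc(N2C(=O)CS/C2=N\c2csc(-c3ccccc3)c2)c1`: in this assay compound 3 gives 38300 nM.

Compound 1 and compound 2 share one core and differ in a single place: methyl in place of hydrogen on an aromatic carbon. That change produced a 1.6-fold lower number from compound 1 to compound 2 (0.22 log units; within the scatter), so the two numbers cannot be told apart with confidence. Compound 3 is built on a different core; the difference between the two cores is not broken down here. Among the three measured compounds, compound 3 stands with the highest number, and its gaps to compound 1 and to compound 2 both lie beyond the scatter.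

Compound 4, `COc1cccc(N2C(=O)CS/C2=N\c2csc(-c3ccc(C)cc3)c2)c1`, has not yet been measured. It is obtained from compound 3 by the same change: methyl in place of hydrogen on an aromatic carbon. Because the earlier step of a 1.6-fold lower number from compound 1 to compound 2 (0.22 log units; within the scatter) stayed within the scatter, the step from compound 3 to compound 4 is also expected to be small, estimated as a 1.4-fold lower number from compound 3 to compound 4 (0.14 log units; within the scatter). On that basis compound 4 is expected to give about 28000 nM in this assay, most likely falling between 12000 nM and 65000 nM.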

Compound 4, half-maximal inhibitory concentration: > 50000 nM
Compound 4 gave a limit, no number; the forecaster's own chance of this, stated with the estimate: 10%; at least 1.7-fold (0.25 log units) between middle value and limit.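

In this assay compound 4 gives > 50000 nM, which is a limit of the assay and not a number. Going from phenyl to 4-methylphenyl gives an at least 1.3-fold higher number from compound 3 to compound 4 (0.11 log units; that floor lies within the scatter), so this step has only a floor and its true size is unknown. The result neither shows that the methyl change carries over from one core to the other nor shows that it behaves differently on the two cores: the same change on two cores in this assay, a 1.6-fold lower number (0.22 log units; within the scatter) from compound 1 to compound 2 and an at least 1.3-fold higher number (0.11 log units; that floor lies within the scatter) from compound 3 to compound 4; the limit leaves it open whether they differ

The compounds shown leave open how an amine or a carboxylic acid in place of the methyl would read in this assay on either core. A true number for compound 4, rather than a limit, would be needed before the two steps could be compared.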